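A few compounds are considered here, and "the series" means these few. Any claim that something is new, unique, unknown or untested is made for them only; others in the source may bear on it.

Measured so far:
compound 1 `CCc1cc(C(C)=O)c(O)cc1OCCCCCCC#N` — 73%
compound 2 `CCc1cc(C(C)=O)c(O)cc1OCCCCC(C)(C)C#N` — 30%

Going by the values given here, compound 1 stands highest of the two numbers in an assay on isolated protein for binding affinity to leukotriene B4 receptor 1 (Homo sapiens), tested at 1 uM; a higher number here means more inhibition at the concentration tested (going by the name of the read-out), a lower number less inhibition; the only measured step, a number 43 percentage points lower from compound 1 to compound 2 (beyond the scatter), is large. Compound 3 `CCc1cc(C(C)=O)c(O)cc1OCCCCCC(C)(C)c1nnnn1C` is not yet measured and differs from compound 1 by 1-methyl-1-(1-methyl-1H-tetrazol-5-yl)ethyl in place of cyanomethyl on a saturated chain carbon, five bonds along the chain from an oxygen on an aromatic ring. That single step bears on it: the entering 1-methyl-1-(1-methyl-1H-tetrazol-5-yl)ethyl carries two methyl groups on one chain carbon, as the 1-cyano-1-methylethyl of compound 2 does, and in addition the nitrile is exchanged for the tetrazole ring. A drop beyond the scatter is therefore expected, a number 43 percentage points lower from compound 1 to compound 3 (beyond the scatter). Compound 3 is estimated at 30%, range 5% to 60%.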

Compound 3, a percentage reported as inhibition, at one concentration (the size of the read-out at that concentration, not a potency): 59%
Estimate against measurement, compound 3: 29 percentage points below, within the range that was stated.
By their numbers in this assay, from the lowest: compound 2; then compound 3; then compound 1.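

In this assay this chain end accepts a much larger group than cyanomethyl, a tetrazole-bearing one, with only a number 14 percentage points lower from compound 1 to compound 3 (beyond the scatter). That step is modest, whereas a number 43 percentage points lower from compound 1 to compound 2 (beyond the scatter) is large, so two methyl groups on one chain carbon do not go with a large drop in every case. No measurement here accounts for the difference between the two steps.

From the compounds shown here alone, the tetrazole and the two methyl groups enter together, and their separate shares remain unknown. Also open, going by these compounds, is how a carboxylic acid or an amine would fare at this chain end.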